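Phenoxy in Place of Phenyl: Compound 3 Awaited

A few compounds are considered here, and "the series" means these few. Any claim that something is new, unique, unknown or untested is made for them only; others in the source may bear on it.

Compound 1 `COc1ccc(Cn2nnc(O)c2C(=O)Nc2cc(C(F)(F)F)cc(C(F)(F)F)c2)cc1` gives 33800 nM
Compound 2 `COc1ccc(Cn2nnc(O)c2C(=O)Nc2ccc(-c3ccccc3)cc2)cc1` gives 57900 nM

In a functional assay on CWR22R cells (Homo sapiens) for inhibition, read by sulforhodamine B assay, with a stated time of 72 h (a lower number here means a stronger inhibitor, a higher number a weaker inhibitor), compound 2 gives 57900 nM, a number within the usual scatter of compound 1 at 33800 nM. Compound 3 `COc1ccc(Cn2nnc(O)c2C(=O)Nc2ccc(Oc3ccccc3)cc2)cc1` carries phenoxy in place of phenyl on an aromatic carbon, para to a large group (phenoxy in place of phenyl on an aromatic carbon). Going by the values given here, no measured pair shows this change, so no step beyond the scatter is expected in this assay, in either direction. The estimated change is small, a 1.2-fold lower number from compound 2 to compound 3 (0.06 log units; within the scatter). Compound 3 is expected at 50000 nM, with an estimated range from 20000 nM to 100000 nM.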

Compound 3, half-maximal inhibitory concentration in the CWR22R assay: 58200 nM
Estimate against measurement, compound 3: 1.2-fold (0.07 log units) below; the range from low to high includes it.
By their numbers in the CWR22R assay, from the lowest: compounds 1, 2 and 3 (each within the scatter of the next).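

In the CWR22R assay, compound 2 gives 57900 nM and compound 3 gives 58200 nM; the only single change shown so far gives a 1.0-fold higher number from compound 2 to compound 3 (0.00 log units; within the scatter), so at this aromatic carbon, para to a large group, phenoxy in place of phenyl stays within the scatter, even with the hydrogen-bond acceptor that phenoxy brings. In a physicochemical assay for lipophilicity, read by spectrophotometry, using the shake flask method, in phosphate buffer, measured as octanol-water partition, with a stated time of 4 h, at pH 7.4 (a higher number here means a more lipophilic compound, a lower number a more polar compound), compound 2 gives 2.19 and compound 3 gives "nd" (no result reported), so the matching step cannot be read. Nothing at hand accounts for this result.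

The compounds shown leave open whether an amine or a carboxylic acid on this carbon would give a step beyond the scatter in the CWR22R assay. They also leave open how single changes elsewhere on the shared core would read.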